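The source may hold more compounds than are shown below. What is called first, only, known or untested is meant among the compounds shown, and "the series" means these compounds.

Compound 1 `S=C1NCCCN1Cc1ccccc1` gives in a functional assay on B16 cells (Mus musculus) for inhibition, with a stated time of 72 h (a lower number here means a stronger inhibitor, a higher number a weaker inhibitor), only a limit, > 10000 nM.
Compound 2 `COc1ccc(CN2CCCNC2=S)cc1` gives 6100 nM in this assay.
Compound 3 `O=C1NCCCN1Cc1ccccc1` gives in this assay only a limit, > 10000 nM.

For the measured compounds named here, the one measured step, an at least 1.6-fold lower number from compound 1 to compound 2 (0.21 log units; that floor lies within the scatter), is methoxy in place of hydrogen on an aromatic carbon. Its size is known only as a floor, which rests on (the limit of > 10000 nM in this assay, at which 2 of the 3 values shown sit). The difference between the core of compound 1 and the core of compound 3 is not broken down here.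

Compound 4 `COc1ccc(CN2CCCNC2=O)cc1` is still to be measured in this assay. It stands to compound 3 as compound 2 stands to compound 1, the same change: methoxy in place of hydrogen on an aromatic carbon.

Beside the earlier step, the step from compound 3 to compound 4 is expected to be an at least 1.1-fold lower number from compound 3 to compound 4 (0.04 log units; that floor lies within the scatter), resting on compound 3 sitting at the limit > 10000 nM and on the floor seen in an at least 1.6-fold lower number from compound 1 to compound 2 (0.21 log units; that floor lies within the scatter). Compound 4 is therefore estimated at 9000 nM, expected between 3000 nM and 30000 nM.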

Compound 4, half-maximal inhibitory concentration: > 10000 nM
Compound 4 was reported as a limit; the forecaster's own chance of this, stated with the estimate: 55%; at least 1.1-fold (0.04 log units) between middle value and limit.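

No step can be read from compound 3 to compound 4, since both stand only as limits in this assay: the limit of > 10000 nM in this assay, at which 3 of the 4 values shown sit.

From the compounds shown here alone, whether methoxy in place of hydrogen on an aromatic carbon shifts the number at all on the core of compound 3 stays open.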